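The compounds below may be only part of what the source reports. "The series", "measured", "known", "first", "only" and "open" are said of these compounds alone.

Measured in a functional assay on Hep 3B2 cells (Homo sapiens) for cytotoxicity, read by XTT assay; a higher number here means a weaker inhibitor, a lower number a stronger inhibitor:
compound 1 `C/C(=C\[C@@H](O)C/C(C)=C/CCc1ccoc1)CC[C@@H](O)[C@]1(C)CCC(=O)O1`: 6400 nM
compound 2 `CC(=O)O[C@H](CC/C(C)=C/[C@@H](O)C/C(C)=C/CCc1ccoc1)[C@]1(C)CCC(=O)O1`: 1100 nM
compound 3 `CC(=O)O[C@H](/C=C(\C)CC[C@@H](O)[C@]1(C)CCC(=O)O1)C/C(C)=C/CCc1ccoc1`: 10600 nM

Compound 3 lies within the scatter of compound 1, with a 1.7-fold higher number from compound 1 to compound 3 (0.22 log units; within the scatter), and both values stand well above that of compound 2. Compound 4 `CC(=O)O[C@H](/C=C(\C)CC[C@@H](OC(C)=O)[C@]1(C)CCC(=O)O1)C/C(C)=C/CCc1ccoc1` is compound 3 with one further change, acetyl in place of hydrogen on an oxygen on a saturated carbon, hydroxy to acetoxy. Within the data shown here, the closest precedent is the same exchange on the same oxygen, a 5.8-fold lower number from compound 1 to compound 2 (0.76 log units; beyond the scatter). Among the measured compounds shown here, no measured compound carries both acetyl groups, so that single precedent is discounted slightly. A lower number is expected, with the estimated change being a 4.2-fold lower number from compound 3 to compound 4 (0.63 log units; beyond the scatter). The estimate for compound 4 is 2500 nM, with an expected range of 1000 nM to 6500 nM.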

Compound 4, half-maximal inhibitory concentration: 7000 nM
For compound 4 the middle estimate is 2.8-fold (0.45 log units) below the measured one; measured number above the stated range.
By their numbers in this assay, from the lowest: compound 2; then compounds 1, 4 and 3 (each within the scatter of the next).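

The acetyl on this oxygen does not act alike on the two cores: with the other hydroxy already acetylated, this assay shows a 1.5-fold lower number from compound 3 to compound 4 (0.18 log units; within the scatter), and the gap to the earlier step is real: the same change on two cores in this assay, a 5.8-fold lower number (0.76 log units; beyond the scatter) from compound 1 to compound 2 and a 1.5-fold lower number (0.18 log units; within the scatter) from compound 3 to compound 4, 3.8-fold (0.58 log units) apart, beyond the scatter of two such steps. The other acetyl also depends on its partner, with a 6.4-fold higher number from compound 2 to compound 4 (0.80 log units; beyond the scatter) once this oxygen carries acetyl: the same change on two cores in this assay, a 1.7-fold higher number (0.22 log units; within the scatter) from compound 1 to compound 3 and a 6.4-fold higher number (0.80 log units; beyond the scatter) from compound 2 to compound 4, 3.8-fold (0.58 log units) apart, beyond the scatter of two such steps. The two acetyl groups do not add up in this series, and only compound 2, with acetyl on this oxygen alone, stands apart. From the compounds shown here alone, whether a methyl ether or a longer acyl chain such as butyryl on this oxygen would behave like acetyl stays open.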